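Expecting a Bromophenyl Amide in the Fibroblast Assay

The source may report more compounds than this note shows. Statements on the series, on what has been measured and on what is new or still open speak of the compounds shown alone.

Measured so far:
compound 1, `CC(C)(C)NC(=O)CCc1cccc2c1B(O)OC2`: > 100000 nM
compound 2, `O=C(CCc1cccc2c1B(O)OC2)Nc1ccc(I)cc1`: 49000 nM
compound 3, `CC(C)(C)OC(=O)NCc1ccc(NC(=O)CCc2cccc3c2B(O)OC3)cc1`: 4800 nM

All three share one core and were tested in an ADME assay on WI-38 cells (Homo sapiens) for cytotoxicity, read by MTT assay, with a stated time of 72 h; on this read-out lower numbers stand for stronger inhibition and higher numbers for weaker inhibition. Compound 1 gives only a limit in this assay, (the limit of > 100000 nM in this assay, at which 1 of the 3 values shown sits), so no number is known for it. Replacing tert-butyl with 4-iodophenyl on the amide-type nitrogen gave an at least 2.0-fold lower number from compound 1 to compound 2 (0.30 log units; that floor lies within the scatter). Going further, from iodo to ((tert-butoxycarbonyl)amino)methyl on the aromatic ring, gave a 10-fold lower number from compound 2 to compound 3 (1.01 log units; beyond the scatter).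

Compound 4 `O=C(CCc1cccc2c1B(O)OC2)Nc1cccc(Br)c1` has not yet been measured. It differs from compound 1 as follows: 3-bromophenyl in place of tert-butyl on an amide-type nitrogen. This change resembles the step from compound 1 to compound 2, since both put a halogen-bearing phenyl ring onto the amide-type nitrogen in place of tert-butyl, so the result for compound 2 is the closest guide. The step from compound 1 to compound 4 in this assay is therefore expected to be an at least 2.0-fold lower number from compound 1 to compound 4 (0.30 log units; that floor lies within the scatter), toward a lower number, though with the limit of compound 1 its size is uncertain. Compound 4 is expected to give about 50000 nM, estimated between 15000 nM and 150000 nM.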

Compound 4, half-maximal inhibitory concentration: 20000 nM
Beside the measured number, compound 4's estimate is 2.5-fold (0.40 log units) above it, and the stated range covers the measured number.
By their numbers in this assay, from the lowest: compound 3; then compound 4; then compound 2. At a limit, above all of these: compound 1.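

With 3-bromophenyl in place of tert-butyl on the amide-type nitrogen, this assay shows an at least 5.0-fold lower number from compound 1 to compound 4 (0.69 log units; beyond the scatter), so this change clears the scatter, which the floor for the step to compound 2 did not. The choice of aromatic group also counts, as 3-bromophenyl in place of 4-iodophenyl gives a 2.5-fold lower number from compound 2 to compound 4 (0.39 log units; beyond the scatter), although this swap alters the halogen and its ring position together, so neither can be credited alone. Compound 1 stands at a limit of the assay, so the size of its step remains a floor: the limit of > 100000 nM in this assay, at which 1 of the 4 values shown sits.

A 4-bromophenyl group on the same nitrogen would separate the halogen from its ring position. As far as these compounds go, whether any halogen is needed remains open, as does what an unsubstituted phenyl, or a phenyl carrying an amine or a carboxylic acid, would give.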